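Swapping the aryl group on the sulfonyl: cytotoxicity outlook

The source may report more compounds than this note shows. Statements on the series, on what has been measured and on what is new or still open speak of the compounds shown alone.

Measured compounds:
Compound 1 `O=S(=O)(Nc1ccc(-c2nc3ccccc3o2)cc1)c1cccs1`: > 100000 nM
Compound 2 `O=S(=O)(Nc1ccc2oc(-c3ccccc3)nc2c1)c1cccs1`: 97000 nM
Compound 3 `C=Cc1ccc(S(=O)(=O)Nc2ccc3oc(-c4ccccc4)nc3c2)cc1`: 53000 nM

Three sulfonamides built on a shared core were tested in an ADME assay on HEK293 cells (Homo sapiens) for cytotoxicity, read by resazurin assay, with a stated time of 48 h; on this read-out higher numbers stand for lower toxicity in this test and lower numbers for higher toxicity in this test. Compound 1 gives only a limit here, namely > 100000 nM; this means no number was reached in the range tested (the limit of > 100000 nM in this assay, at which 1 of the 3 values shown sits). Compound 2 gives 97000 nM in this assay, and compound 3 gives 53000 nM. Within the data shown here, the only one-place step among them, a 1.8-fold lower number from compound 2 to compound 3 (0.26 log units; within the scatter), shows that exchanging the ring on the sulfonyl sulfur leaves this read-out essentially unchanged.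

The unmeasured compound 4 `O=S(=O)(Nc1ccc(-c2nc3ccccc3o2)cc1)c1ccc(F)cc1` differs from compound 1 in one place: 4-fluorophenyl in place of thiophen-2-yl on a sulfonyl sulfur. This is the same kind of exchange as in the step from compound 2 to compound 3, which stayed within the scatter, so no movement beyond the scatter is expected in this assay, and the result may again come back as a limit. Compound 4 is therefore expected to give about 100000 nM, between 50000 nM and 200000 nM, a step of a number no higher from compound 1 to compound 4 (the limit leaves the size open) expected from its parent.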

Compound 4, half-maximal cytotoxic concentration: > 100000 nM
Compound 4 was reported as a limit; the forecaster's own chance of this, stated with the estimate: 55%; the middle value sits exactly at the limit.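

Compound 1 and compound 4 both stand as limits in this assay, so no step can be read between them: the limit of > 100000 nM in this assay, at which 2 of the 4 values shown sit.

The compounds shown leave open whether 4-fluorophenyl in place of thiophen-2-yl on a sulfonyl sulfur changes this read-out at all on the core of compound 1.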